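The compounds below may be only part of what the source reports. "The series", "measured", "known", "first", "only" and "open" are said of these compounds alone.

Two compounds share one core and differ only in the aryl group attached to it. Compound 1 `COc1cccc(-c2nc(C(F)(F)F)n(CC[C@@H](O)C[C@@H](O)CC(=O)O)c2-c2ccc(F)cc2)c1` carries a 3-methoxyphenyl there, and in an assay on microsomes from liver for inhibition of 3-hydroxy-3-methylglutaryl-coenzyme A reductase (Rattus norvegicus) (on this read-out higher numbers stand for weaker inhibition and lower numbers for stronger inhibition), compound 1 gives 20 nM. Compound 2 `Cc1ccc(-c2nc(C(F)(F)F)n(CC[C@@H](O)C[C@@H](O)CC(=O)O)c2-c2ccc(F)cc2)cc1` carries a 4-methylphenyl instead, and in this assay compound 2 gives 43 nM. Of the two numbers, compound 2 has the higher one: the step of a 2.2-fold higher number from compound 1 to compound 2 (0.33 log units; beyond the scatter) is modest but beyond the scatter. Compound 3 `COc1ccc(-c2nc(C(F)(F)F)n(CC[C@@H](O)C[C@@H](O)CC(=O)O)c2-c2ccc(F)cc2)cc1` is the next member. Here (methoxy in place of methyl on an aromatic carbon), so the aryl group becomes a 4-methoxyphenyl. Going by the values given here, no measured step exchanges a methyl for a methoxy on the same carbon; the only step at hand, a 2.2-fold higher number from compound 1 to compound 2 (0.33 log units; beyond the scatter), swaps a 3-methoxyphenyl for a 4-methylphenyl, and it is modest. From that alone, only a small movement in this assay seems likely, if any, with a slight lean towards a lower number. Compound 3 is therefore expected to give about 30 nM in this assay, between 12 nM and 75 nM, which is expected to correspond to the step of a 1.4-fold lower number from compound 2 to compound 3 (0.16 log units; within the scatter).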

Compound 3, half-maximal inhibitory concentration: 68 nM
For compound 3 the middle estimate is 2.3-fold (0.36 log units) below the measured one, within the range that was stated.
By their numbers in this assay, from the lowest: compound 1; then compounds 2 and 3 (each within the scatter of the next).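

In this assay, replacing the methyl of the 4-methylphenyl with a methoxy on the same ring carbon, para to a large group, gives a 1.6-fold higher number from compound 2 to compound 3 (0.20 log units; within the scatter), so this exchange does not separate the two compounds, although the methoxy adds one oxygen and one hydrogen-bond acceptor. Moving the methoxy group itself, from the 3-methoxyphenyl to the 4-methoxyphenyl, gives a 3.4-fold higher number from compound 1 to compound 3 (0.53 log units; beyond the scatter), which is a modest step but a real one, and it shows that with the same group on the aryl ring, where that group sits can change the number more than the exchange of methyl for methoxy did. No measurement at hand accounts for either result.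

The compounds shown leave open whether a 3-methylphenyl would read like the 3-methoxyphenyl, which would show whether the placement matters for groups other than methoxy. They also leave open how an unsubstituted phenyl, or an amine or a longer chain such as ethoxy on the same ring carbon, would read in this assay.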